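Swapping the aryl group on a shared core

The source may hold more compounds than are shown below. What is called first, only, known or untested is meant among the compounds shown, and "the series" means these compounds.

Measured so far:
compound 1 `CC(C)n1nc(-c2ccnc3[nH]c(C4CCN(CC(=O)N(C)C)CC4)cc23)ccc1=O` — 3.1 uL/min
compound 2 `CC(=O)N1CCC(c2cc3c(-c4ccc(=O)n(C(C)C)c4)ccnc3[nH]2)CC1` — 2.8 uL/min

In an ADME assay on cells (Hepatocyte, Rattus norvegicus) for metabolic stability (a lower number here means slower removal, a higher number faster removal of the compound), compound 1 gives 3.1 uL/min. Of the two numbers recorded it is the higher, yet compound 2 at 2.8 uL/min sits within the scatter of it, so the two compounds cannot be ordered; both are removed slowly in this assay.

Compound 3 `COc1cc(=O)n(C)cc1-c1ccnc2[nH]c(C3CCN(CC(=O)N(C)C)CC3)cc12` has not yet been measured. It differs from compound 1 in a single place: a group of 10 heavy atoms (7 carbon, 1 nitrogen, 2 oxygen; one six-membered aromatic ring with 1 hetero atom) in place of a group of 10 heavy atoms (7 carbon, 2 nitrogen, 1 oxygen; one six-membered aromatic ring with 2 hetero atoms), on an aromatic carbon. Within the data shown here, no step between two measured compounds covers a change of this kind, and the only other measured compound, compound 2, carries a different group altogether on the same side of the shared core, so there is nothing to set a direction. With both measured compounds sitting low and close together, the step of a 1.0-fold lower number from compound 1 to compound 3 (0.01 log units; within the scatter) is expected to stay within the scatter, in either direction. Compound 3 is therefore expected to come out near 3 uL/min, with a range from 1.5 uL/min to 6.5 uL/min.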

Compound 3, intrinsic clearance in a liver preparation (reported as CLH), per the amount of preparation that the assay uses: < 1 uL/min
Compound 3: only a limit was reported (the forecaster's own chance of this, stated with the estimate: 5%); middle value at least 3.0-fold (0.47 log units) from the limit.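

For compound 3 the reading in this assay is a limit of the assay and not a number: < 1 uL/min. Among these compounds, exchanging the group on the aromatic carbon opposite the ring nitrogen gives an at least 3.1-fold lower number from compound 1 to compound 3 (0.49 log units; beyond the scatter), so this position, for which the earlier compounds offered no step at all, does move the read-out when a six-membered aromatic ring with 2 hetero atoms gives way to one with 1 hetero atom. How far the step reaches cannot be told, because the reading stops at a limit: the limit of < 1 uL/min in this assay, at which 1 of the 3 values shown sits.

The exchange alters several things at once, namely the ring atoms, the methoxy group and the methyl in place of the isopropyl on the ring nitrogen, and the compounds shown do not separate these parts or say which of them carries the step. Also open, from the compounds shown here alone, is whether an ethoxy group or an amine in place of the methoxy group would read the same way, and whether the same exchange would give a comparable step with the acetyl group of compound 2 on the other side of the shared core.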